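The compounds below may be only part of what the source reports. "The series", "measured", "known", "first", "only" and "open" are said of these compounds alone.

Within the data shown here, in a functional assay for antagonist activity at transient receptor potential cation channel subfamily V member 1 (Homo sapiens), read by FLIPR and calcium flux (a lower number here means a less potent compound, a higher number a more potent compound, by a factor of ten per unit of this negative logarithm), compound 3 `CN1CCCc2ccc(NC(=O)c3ccc(-c4ccsc4)cc3)cc21` gives 7.8, the highest of the three numbers measured so far. Compound 2 `CN1CCCc2ccc(NC(=O)c3ccc(-c4cccs4)cc3)cc21` gives 7.6, and the step of a number 0.20 log units higher from compound 2 to compound 3 (within the scatter) stays within the scatter, so these two cannot be ranked. Compound 1 `CC(=O)c1cccc(-c2ccc(C(=O)Nc3ccc4c(c3)N(C)CCC4)cc2)c1` gives 7; here the steps of a number 0.60 log units higher from compound 1 to compound 2 (beyond the scatter) and a number 0.80 log units higher from compound 1 to compound 3 (beyond the scatter) are both beyond the scatter, which shows that exchanging the ring at this position shifts potency modestly.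

Compound 4 `CN1CCCc2ccc(NC(=O)c3ccc(-c4cncnc4)cc3)cc21` differs from compound 3 in one place: pyrimidin-5-yl in place of thiophen-3-yl on an aromatic carbon. Among the measured compounds shown here, no measured step shows this exact exchange. For the measured compounds named here, the steps that bear on it are those from compound 1 to the two thiophenes, both modest gains, and the step between the two thiophenes, which was within the scatter. Since the pyrimidinyl ring is neither of the groups already tested, a modest loss or no change beyond the scatter seems most plausible, and the expected step is a number 0.60 log units lower from compound 3 to compound 4 (beyond the scatter). Compound 4 is therefore estimated to give 7.2 in this assay, with a range from 6.5 to 7.9.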

Compound 4, negative logarithm of the antagonist equilibrium constant: 6.9
The estimate for compound 4 lay 0.30 log units above the measured number, within the range that was stated.
By their numbers in this assay, from the lowest: compounds 4 and 1 (each within the scatter of the next); then compounds 2 and 3 (each within the scatter of the next).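

Pyrimidin-5-yl at this position shows that a ring exchange here can lose potency as well as gain it: in this assay the exchange gives a number 0.90 log units lower from compound 3 to compound 4 (beyond the scatter) and also a number 0.70 log units lower from compound 2 to compound 4 (beyond the scatter) against the other thiophene. The comparison with the 3-acetylphenyl group gives a number 0.10 log units lower from compound 1 to compound 4 (within the scatter) and so does not rank those two groups, which means the gain seen with the thiophenes does not extend to every aromatic ring at this position. No measurement here explains the loss.

Pyrimidin-5-yl differs from thiophen-3-yl in both ring size and hetero atoms, so these compounds do not separate the two changes. Going by these compounds, an unsubstituted phenyl ring and a pyridin-3-yl ring remain open comparisons that could help to separate them.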